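The source may hold more compounds than are shown below. What is called first, only, known or untested is meant among the compounds shown, and "the series" means these compounds.

Measured compounds in an assay on CHO cells for displacement of a labelled ligand from Neuronal acetylcholine receptor; alpha3/alpha6/beta2/beta3 (Homo sapiens), read by scintillation counting; on this read-out higher numbers stand for weaker inhibition and lower numbers for stronger inhibition: compound 1 `CC(=O)N1CC2CC(C1)N2` gives 610 nM; compound 2 `O=C([C@@H]1C[C@@H]1F)N1CC2CC(C1)N2` gives 55 nM; compound 3 `O=C([C@@H]1C[C@H]1F)N1CC2CC(C1)N2` gives 43 nM.

Compound 3 has the lowest number of the three. Its nearest neighbour is compound 2, a gap within the scatter; the far one is compound 1, with a gap beyond the scatter. The gap between compound 2 and compound 3 is a 1.3-fold lower number from compound 2 to compound 3 (0.11 log units; within the scatter), and the only thing distinguishing their drawings is the fact that one of compounds 2 and 3 is drawn with a defined configuration and the other without, at the place where they differ.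

Compound 4 `C[C@@H]1C[C@@H]1C(=O)N1CC2CC(C1)N2` differs from compound 3 by a group of 4 heavy atoms (4 carbon; one three-membered non-aromatic ring of carbon only) in place of a group of 4 heavy atoms (3 carbon, 1 fluorine; one three-membered non-aromatic ring of carbon only), on a carbonyl carbon. Going by the values given here, no measured step isolates the fluorine of the 2-fluorocyclopropyl; the steps that bear on the change are a 14-fold lower number from compound 1 to compound 3 (1.15 log units; beyond the scatter) and an 11-fold lower number from compound 1 to compound 2 (1.04 log units; beyond the scatter), both showing that moving from methyl to a substituted three-membered ring on the carbonyl carbon brings a large gain, and a 1.3-fold lower number from compound 2 to compound 3 (0.11 log units; within the scatter), showing that the drawn configuration at the ring carbon makes little difference. Compound 4 keeps the three-membered ring and its two defined stereocentres, so most of that gain is expected to be retained, with some uncertainty about the methyl in place of fluorine; the expected step is a 1.5-fold higher number from compound 3 to compound 4 (0.18 log units; within the scatter), likely within or near the scatter in the weaker direction. In this assay compound 4 is therefore estimated at 65 nM, expected between 20 nM and 220 nM.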

Compound 4, inhibition constant: 92 nM
Compound 4: middle estimate off by 1.4-fold (0.15 log units), on the low side, and the stated range covers the measured number.
By their numbers in this assay, from the lowest: compounds 3, 2 and 4 (each within the scatter of the next, the first and the last beyond it); then compound 1.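

In this assay, the step of a 6.6-fold lower number from compound 1 to compound 4 (0.82 log units; beyond the scatter) shows that a three-membered ring of carbon only on the carbonyl carbon still improves on methyl, so the gain at this position does not depend on fluorine. Compared with the two 2-fluorocyclopropyl amides, the reading is split: the step of a 2.1-fold higher number from compound 3 to compound 4 (0.33 log units; beyond the scatter) lies beyond the scatter and is modest, whereas the step of a 1.7-fold higher number from compound 2 to compound 4 (0.22 log units; within the scatter) lies within it. Exchanging fluorine for carbon in this group therefore has at most a modest cost, and whether any cost can be seen depends on which fluorinated compound serves as the reference; nothing measured here gives a reason for these steps.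

Open, on these data alone, is how an unsubstituted cyclopropyl or a cyclobutyl would read on this carbonyl carbon, which would show how much of the gain over methyl comes with the ring alone. Also open, as far as these compounds go, is how the other configurations of the methyl-bearing ring would compare with compound 4, and whether a hydroxyl or an amine on the ring would be tolerated.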